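This account rests on a few compounds, and the source may have more. Where it says the series, first, only, none or still open, it means among the compounds named here.

Measured compounds in an assay on Sf9 cells for inhibition of Leucine-rich repeat serine/threonine-protein kinase 2 (Homo sapiens), read by TR-FRET, with stated times of 30 min and 2 h; on this read-out lower numbers stand for stronger inhibition and higher numbers for weaker inhibition:
- compound 1 `O=C(Nc1ccnnc1)c1cc(N2CCCCC2)ccc1OCc1ccccc1`: 25.1 nM
- compound 2 `O=C(Nc1ccnnc1)c1cc(N2CCC(F)CC2)ccc1OCc1ccccc1`: 39.8 nM
- compound 3 `CN1CC2(C1)CN(c1ccc(OCc3ccccc3)c(C(=O)Nc3ccnnc3)c1)C2`: 25.1 nM

Compound 1 stands level with compound 3 in this assay, the two together giving the lowest numbers of the three; compound 2 sits furthest from it, but still close, as the step of a 1.6-fold higher number from compound 1 to compound 2 (0.20 log units; within the scatter) shows. All three compounds lie within the scatter of one another, so no order among them can be read.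

Compound 4 `CN1CC2(CCN(c3ccc(OCc4ccccc4)c(C(=O)Nc4ccnnc4)c3)CC2)C1` is not yet measured. Relative to compound 1 the change is a group of 10 heavy atoms (8 carbon, 2 nitrogen; one four-membered non-aromatic ring with 1 hetero atom, one six-membered non-aromatic ring with 1 hetero atom) in place of a group of 6 heavy atoms (5 carbon, 1 nitrogen; one six-membered non-aromatic ring with 1 hetero atom), on an aromatic carbon.

Among the measured compounds shown here, the step that bears most directly on this is the one from compound 1 to compound 3, where the same piperidin-1-yl group gives way to a larger group of two four-membered rings: no change at the digits printed from compound 1 to compound 3 (within the scatter). The related step of a 1.6-fold lower number from compound 2 to compound 3 (0.20 log units; within the scatter) is likewise within the scatter. The change to compound 4 again enlarges the group on the same aromatic carbon, now by a four-membered ring joined to a six-membered ring, and nothing in the measured steps suggests that enlarging this group moves this assay beyond the scatter. The expected step is therefore a 1.1-fold higher number from compound 1 to compound 4 (0.05 log units; within the scatter), essentially none beyond the scatter.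

Compound 4 is thus estimated at 28 nM in this assay, within a range of 12 nM to 65 nM.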

Compound 4, half-maximal inhibitory concentration: 63.1 nM
Estimate against measurement, compound 4: 2.3-fold (0.35 log units) below, within the range that was stated.
By their numbers in this assay, from the lowest: compounds 1, 3, 2 and 4 (each within the scatter of the next, the first and the last beyond it).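

Among the compounds shown here, at the aromatic carbon meta to the (pyridazin-4-yl)carbamoyl group and para to the benzyloxy group, enlargement of the amine group now has a readable cost in this assay: the first steps beyond the scatter are a 2.5-fold higher number from compound 1 to compound 4 (0.40 log units; beyond the scatter) and a 2.5-fold higher number from compound 3 to compound 4 (0.40 log units; beyond the scatter). The tolerance seen for the group of compound 3 therefore does not extend to the group of 10 heavy atoms, although this holds only against compound 1 and compound 3, since the comparison with the fluoro-bearing compound goes the other way in reading, with a 1.6-fold higher number from compound 2 to compound 4 (0.20 log units; within the scatter) staying within the scatter. No measurement available here bears on the origin of this modest step.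

The compounds shown leave open whether the step follows the overall size of the entering group or its particular arrangement of a four-membered ring joined to a six-membered ring, which the same group without its methyl or a ring-opened dimethylaminomethyl chain could help separate. They also leave open how a morpholin-4-yl group or a carboxylic acid on a piperidine would read at this position.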